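Vero cell toxicity: from compound 3 to compound 4

This account rests on a few compounds, and the source may have more. Where it says the series, first, only, none or still open, it means among the compounds named here.

compound 1 `Oc1cccc(Nc2nc(NCc3ccccc3)nc3[nH]cnc23)c1`: > 150000 nM
compound 2 `CC(=O)c1ccc(Nc2nc(NCCO)nc3[nH]cnc23)cc1`: 160000 nM
compound 3 `OCCNc1nc(Nc2cccc(O)c2)c2nc[nH]c2n1`: > 175000 nM

In an ADME assay on Vero cells (Chlorocebus sabaeus) for cytotoxicity (on this read-out lower numbers stand for higher toxicity in this test and higher numbers for lower toxicity in this test), compound 1 gives > 150000 nM, which is a limit of the test and not a number. Compound 2 gives 160000 nM in this assay. Compound 3 gives > 175000 nM in this assay, again a limit rather than a number. Compound 3 therefore stands at the upper end of what this assay reports; of the three values, one sits at the limit of > 150000 nM in this assay, at which 1 of the 3 values shown sits, and compound 3 itself sits at the limit of > 175000 nM in this assay, at which 1 of the 3 values shown sits. Going by the values given here, the only step between two measured compounds that differ in one place, a step that the two limits leave unreadable from compound 1 to compound 3, runs from one limit to another and cannot be read.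

Compound 4 `CC(C)CCNc1nc(Nc2cccc(O)c2)c2nc[nH]c2n1` differs from compound 3 as isopropyl in place of hydroxy on a saturated chain carbon, two bonds along the chain from a nitrogen on an aromatic ring. Among the compounds with values here, no measured step bears directly on this change: the single step available is unreadable, and compound 2, the only compound with an actual number, differs from compound 3 in more than one place. With all three measured values sitting in the same region of the read-out, compound 4 is expected to show no step beyond the scatter, an at least 1.1-fold lower number from compound 3 to compound 4 (0.06 log units; that floor lies within the scatter). The estimate for compound 4 is 150000 nM, expected to fall between 60000 nM and 300000 nM.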

Compound 4, half-maximal cytotoxic concentration: 151000 nM
Compound 4: middle estimate off by 1.0-fold (0.00 log units), on the low side; low and high end bracket the measured number.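

In this assay, going by these compounds alone, isopropyl in place of hydroxy on a saturated chain carbon, two bonds along the chain from a nitrogen on an aromatic ring, gives the one readable step at this position, an at least 1.1-fold lower number from compound 3 to compound 4 (0.06 log units; that floor lies within the scatter). This shows that exchanging the 2-hydroxyethyl chain for isopentyl, which removes the hydroxy group's hydrogen-bond donor and acceptor, gives no step shown to lie beyond the scatter, though the step is readable only as a floor because compound 3 is reported at a limit of the test and not as a number: the limit of > 175000 nM in this assay, at which 1 of the 4 values shown sits. The steps that involve compound 1 cannot be read, so the phenyl-bearing side chain offers no comparison with either the 2-hydroxyethyl or the isopentyl chain.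

As far as these compounds go, how far the number from compound 3 to compound 4 truly moves remains open, since only its floor is known. Also open, from the compounds shown here alone, is whether an amine or a carboxylic acid at the end of this chain, or a longer chain, would give a number clearly lower than those of compound 3 and compound 4 in this assay.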